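Swapping bromo for phenyl: a step into the unknown

This account rests on a few compounds, and the source may have more. Where it says the series, first, only, none or still open, it means among the compounds named here.

Measured in a functional assay on CUTLL1 cells (Homo sapiens) for inhibition, read by resazurin assay, with a stated time of 48 h, in the absence of a further agent (a lower number here means that less compound is needed, a higher number that more compound is needed for the effect), as follows
Compound 1 `Nc1ncc(-c2ccnc3ccccc23)c(C2CC2)n1` gives > 100000 nM as a limit
Compound 2 `Nc1ncc(-c2ccc(F)cc2)c(C2CC2)n1` gives > 100000 nM as a limit
Compound 3 `Nc1ncc(-c2ccncc2Br)c(C2CC2)n1` gives 99000 nM as a number

Going by the values given here, compound 3 at 99000 nM holds the only actual number in this small set. Compound 1 and compound 2 stand at the limit of > 100000 nM in this assay, at which 2 of the 3 values shown sit, and so offer no exact number for comparison.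

Compound 4 `Nc1ncc(-c2ccncc2-c2ccccc2)c(C2CC2)n1` has phenyl in place of bromo on an aromatic carbon of a six-membered aromatic ring with 1 nitrogen (phenyl in place of bromo on an aromatic carbon). Among the compounds with values here, no two measured compounds differ in one place only, so no earlier step can serve as a guide. A modest move toward a lower number in this assay is expected, although a result within the scatter of compound 3 or at the limit would be no surprise. The estimated change is a step (a 2.5-fold lower number from compound 3 to compound 4 (0.39 log units; beyond the scatter)) of modest size. For compound 4 the estimated value is 40000 nM with an expected range from 8000 nM to 100000 nM as a working expectation.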

Compound 4, half-maximal effective concentration: > 100000 nM
Compound 4: no number, only a limit; the forecaster's own chance of this, stated with the estimate: 35%; at least 2.5-fold (0.39 log units) between middle value and limit.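

Putting phenyl, with its six carbon atoms and its own ring, in place of bromo on this aromatic carbon brings no lower number in this assay. Compound 4 gives > 100000 nM, which is a limit and not a number. The change from bromo to phenyl gives a number no lower from compound 3 to compound 4 (the limit leaves the size open), so the size of the step cannot be read. This is the first comparison of two compounds that differ in one place, and it shows that a ring of carbon at this position does not bring the value below the limit, leaving compound 3 as the only compound with an actual number: the limit of > 100000 nM in this assay, at which 3 of the 4 values shown sit.

As far as these compounds go, how far compound 4 lies beyond its limit stays open. So does the question of whether an amine or a carboxylic acid on this aromatic carbon would give a lower number.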